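The compounds below may be only part of what the source reports. "The series", "measured", "known", "first", "only" and "open" are said of these compounds alone.

Within the data shown here, compound 3 `CCOC(=O)C1=C(C)N/C(=N\C#N)NC1c1ccsc1` is one of three compounds measured in an assay on HeLa cells for displacement of a labelled ligand from adenosine receptor A3 (Homo sapiens), with a stated time of 180 min, tested at 1 uM; on this read-out higher numbers stand for more inhibition at the one concentration tested (going by the name of the read-out) and lower numbers for less inhibition. In this assay compound 3 gives 23%, and it stands at the upper end of the three numbers: compound 2 `CC1=C(C(=O)OC(C)C)C(c2ccsc2)N/C(=N/C#N)N1` gives 13% and lies within the scatter of it, while compound 1 `CC1=C(C(=O)OC(C)C)[C@@H](c2ccco2)N/C(=N/C#N)N1` gives 4% and lies beyond the scatter below it. Among the measured compounds shown here, the one step between measured compounds that differ in a single place, a number 10 percentage points higher from compound 2 to compound 3 (within the scatter), concerns the ester and not the aromatic ring. Compound 4 `CCOC(=O)C1=C(C)N/C(=N\C#N)NC1c1ccccc1` differs from compound 3 as follows: phenyl in place of thiophen-3-yl on a saturated ring carbon. For the measured compounds named here, no measured step changes this ring, so no step bears on the change directly; compound 1 and compound 2 differ at this position, but they also differ elsewhere, and their two values show only a gap beyond the scatter. Compound 4 is therefore expected to sit close to compound 3, with a step of a number 3 percentage points lower from compound 3 to compound 4 (within the scatter). Compound 4 is estimated at 20%, within a range from 5% to 40%.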

Compound 4, a percentage reported as inhibition, at one concentration (the size of the read-out at that concentration, not a potency): 13%
Beside the measured number, compound 4's estimate is 7 percentage points above it; the measured number falls inside the stated range.
By their numbers in this assay, from the lowest: compounds 1, 2, 4 and 3 (each within the scatter of the next, the first and the last beyond it).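

The change in this assay gives a number 10 percentage points lower from compound 3 to compound 4 (within the scatter) and so does not tell phenyl from thiophen-3-yl on this saturated ring carbon, with the ethoxycarbonyl group and the rest of the structure held the same. Among these compounds, this is the first reading of this position in which nothing else differs, and it shows that a six-membered aromatic ring of carbon only and a five-membered aromatic ring with sulfur stand within the scatter of each other here. Nothing available accounts for this result.

As far as these compounds go, whether a phenyl ring carrying a methoxy group or a chlorine atom, or a saturated cyclohexyl group at this place, would give a number beyond the scatter of compound 3 remains open. So does whether the same change would read alike with the larger ester of compound 2.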